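From Chloro to Fluoro on the Aromatic Ring

The compounds below may be only part of what the source reports. "The series", "measured", "known", "first", "only" and "open" are said of these compounds alone.

Going by the values given here, compound 2 `CCC1(CCCCN2CC=C(c3ccc(Cl)cc3)CC2)C(=O)Nc2ccccc21` gives 1.02 nM in an assay on CHO cells for displacement of a labelled ligand from 5-hydroxytryptamine receptor 7 (Homo sapiens) (on this read-out higher numbers stand for weaker inhibition and lower numbers for stronger inhibition), the lowest of the two numbers known; compound 1 `CC(C)CC1(CCCCN2CCN(c3cccc(Cl)c3)CC2)C(=O)Nc2ccccc21` gives 1.8 nM, and the gap between them lies within the usual scatter, so the two cannot be ordered. Compound 3 `CCC1(CCCCN2CC=C(c3ccc(F)cc3)CC2)C(=O)Nc2ccccc21` differs from compound 2 in one place: fluoro in place of chloro on an aromatic carbon. Among the compounds with values here, no measured pair shows this change here, so its effect is unknown. Compound 3 is expected to give a slightly higher number, a step of a 2.5-fold higher number from compound 2 to compound 3 (0.39 log units; beyond the scatter) that may stay within the scatter, with an estimate of 2.5 nM, ranging from 0.8 nM to 8 nM.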

Compound 3, inhibition constant: 1.19 nM
For compound 3 the middle estimate is 2.1-fold (0.32 log units) above the measured one; the range from low to high includes it.
By their numbers in this assay, from the lowest: compounds 2, 3 and 1 (each within the scatter of the next).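

In this assay, the exchange of 4-chlorophenyl for 4-fluorophenyl comes to a 1.2-fold higher number from compound 2 to compound 3 (0.07 log units; within the scatter) and so leaves compound 2 and compound 3 unordered. Going by these compounds alone, this gives the first direct reading at this position, para to a large group, where the two halogens cannot be told apart. No data shown here explain this result.

As far as these compounds go, whether a methoxy group, a nitrile or a plain hydrogen in this same place would read like fluoro and chloro stays open. So does whether the same exchange would read alike on the core of compound 1.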